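Methyl on an Amide Nitrogen and Cell Toxicity

The source may report more compounds than this note shows. Statements on the series, on what has been measured and on what is new or still open speak of the compounds shown alone.

Three measured compounds share a common theme in a cell toxicity test. Compound 1 has the structure `NC(=O)c1ncc([N+](=O)[O-])[nH]1`. In a toxicity assay on HEK293 cells (Homo sapiens) for inhibition, read by resazurin assay, with a stated time of 24 h (on this read-out higher numbers stand for lower toxicity in this test and lower numbers for higher toxicity in this test), compound 1 gives > 100000 nM, which is a limit of the assay rather than a number. Compound 2, `CNC(=O)c1ncc([N+](=O)[O-])[nH]1`, differs from compound 1 by methyl in place of hydrogen on an amide-type nitrogen. In this assay compound 2 gives > 100000 nM, again a limit and not a number. The step that the two limits leave unreadable from compound 1 to compound 2 therefore cannot be read. Compound 3, `CNC(=O)c1nc([N+](=O)[O-])cn1Cc1ccc(OC(F)(F)F)cc1`, is built on a different core; the difference between the two cores is not broken down here. In this assay compound 3 gives > 100000 nM, which is a limit of the assay. All three values sit at the limit of > 100000 nM in this assay, at which 3 of the 3 values shown sit.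

Compound 4, `CN(C)C(=O)c1nc([N+](=O)[O-])cn1Cc1ccc(OC(F)(F)F)cc1`, is not yet measured. It differs from compound 3 by methyl in place of hydrogen on an amide-type nitrogen. Among the compounds with values here, this is the same kind of change as from compound 1 to compound 2, though here the amide-type nitrogen also has a saturated chain carbon as a neighbour, where in compound 1 its only other neighbour is the carbonyl carbon. Because all three measured compounds sit at the limit of > 100000 nM in this assay, at which 3 of the 3 values shown sit, compound 4 is expected to stay at the limit too, a step that the limit leaves unreadable from compound 3 to compound 4. The estimate for compound 4 is 150000 nM, between 60000 nM and 400000 nM.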

Compound 4, half-maximal cytotoxic concentration: > 100000 nM
Compound 4 ended at the assay's limit; the forecaster's own chance of this, stated with the estimate: 85%; the middle value lies beyond the limit too.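

On these data alone, no new step can be read: compound 3 and compound 4 each give only a limit of the assay rather than a number, so what the added methyl does to toxicity stays unknown. The compounds shown leave open whether any change among them alters toxicity in this assay, with every result stopping at one point: the limit of > 100000 nM in this assay, at which 4 of the 4 values shown sit.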